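The compounds below may be only part of what the source reports. "The series", "measured", "known", "first", "only" and "open" are said of these compounds alone.

Compound 1 `C[C@H](Oc1ccc(S(C)(=O)=O)cc1C(=O)N1Cc2cc(C(F)(F)F)cnc2C1)C(F)(F)F` and compound 2 `C[C@H](Oc1ccc(S(C)(=O)=O)cc1C(=O)N1Cc2ccc(C3CCOCC3)cc2C1)C(F)(F)F` share the same side chain but differ in the core; the difference between the two cores is not broken down here. In a functional assay on the whole organism for inhibition, with Mus musculus as the target, with a stated time of 60 min (on this read-out higher numbers stand for an effect only at larger amounts of compound and lower numbers for an effect already at smaller amounts), compound 1 gives 0.4 mg/kg and compound 2 gives 0.5 mg/kg, two values within the usual scatter of each other. Compound 3 `CC(C)Oc1ccc(S(C)(=O)=O)cc1C(=O)N1Cc2cc(C(F)(F)F)cnc2C1` carries the core of compound 1 with the change (isopropyl in place of 1-(trifluoromethyl)ethyl on an oxygen on an aromatic ring). In this assay compound 3 gives 1 mg/kg, a step of a 2.5-fold higher number from compound 1 to compound 3 (0.40 log units; beyond the scatter). Compound 4 `CC(C)Oc1ccc(S(C)(=O)=O)cc1C(=O)N1Cc2ccc(C3CCOCC3)cc2C1` applies the same change to compound 2: isopropyl in place of 1-(trifluoromethyl)ethyl on an oxygen on an aromatic ring. The step from compound 2 to compound 4 is expected to be about as large as the measured one, a 2.5-fold higher number from compound 2 to compound 4 (0.40 log units; beyond the scatter), because compound 1 to compound 3 gave a 2.5-fold higher number from compound 1 to compound 3 (0.40 log units; beyond the scatter) on an otherwise identical side chain. Compound 4 is therefore estimated at 1.25 mg/kg, most likely between 0.6 mg/kg and 2.5 mg/kg.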

Compound 4, dose for 50% inhibition: 0.5 mg/kg
For compound 4 the middle estimate is 2.5-fold (0.40 log units) above the measured one; measured number below the stated range.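

On the core of compound 2, isopropyl in place of 1-(trifluoromethyl)ethyl gives no change at the digits printed from compound 2 to compound 4 (within the scatter) in this assay. Set beside the earlier step, the two do not separate: the same change on two cores in this assay, a 2.5-fold higher number (0.40 log units; beyond the scatter) from compound 1 to compound 3 and no change at the digits printed (within the scatter) from compound 2 to compound 4, 2.5-fold (0.40 log units) apart, within the scatter of two such steps. Going by these compounds alone, this fits a change that carries from one core to the other, yet only one of the two steps lies beyond the scatter, so a pair of cores neither establishes a transferable step nor shows that the core alters it.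

Open, going by these compounds, is whether a methyl or a longer chain on the oxygen on the aromatic ring would follow the same course. Also open, on these data alone, is how the opposite stereocentre of 1-(trifluoromethyl)ethyl would read on either core.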